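A few compounds are considered here, and "the series" means these few. Any claim that something is new, unique, unknown or untested is made for them only; others in the source may bear on it.

Measured in a functional assay on MCF7 cells (Homo sapiens) for cytotoxicity, read by MTT assay, with a stated time of 24 h; a higher number here means a weaker inhibitor, a lower number a stronger inhibitor:

- Compound 1 `O=C(NC(=S)Nc1nc2ccccc2s1)c1ccccc1`: 37300 nM
- Compound 2 `O=C(NC(=S)Nc1nc2cc(Br)ccc2s1)N1CCOCC1`: 18100 nM
- Compound 3 `O=C(NC(=S)Nc1nc2cc([N+](=O)[O-])ccc2s1)N1CCOCC1`: 31000 nM

Compound 2 gives the lowest of these three numbers, 18100 nM. That gives it no real lead over its nearest neighbour, as the data show a 1.7-fold higher number from compound 2 to compound 3 (0.23 log units; within the scatter). Compound 1, at 37300 nM, lies furthest away, with a gap only just beyond the usual scatter.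

The next compound, compound 4 `CCCCC(=O)NC(=S)Nc1nc2cc(Br)ccc2s1`, has butyl in place of morpholin-4-yl on a carbonyl carbon. Among the compounds with values here, no measured step covers this change directly. Within the data shown here, the one available step, a 1.7-fold higher number from compound 2 to compound 3 (0.23 log units; within the scatter), is a swap of nitro for bromo on an aromatic carbon, so it concerns a different place in the molecule. Among the measured compounds shown here, it shows only that one change elsewhere stayed within the scatter. Compound 1 also carries a different group on the carbonyl carbon, but it differs from compound 2 in a second place too, so it cannot isolate this change.

With so little to go on, no step beyond the scatter is expected in this assay, and no direction can be favoured. The expected change is a 1.2-fold higher number from compound 2 to compound 4 (0.08 log units; within the scatter). The estimate for compound 4 is 22000 nM, with an expected range from 9000 nM to 50000 nM.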

Compound 4, half-maximal inhibitory concentration: 45700 nM
Estimate against measurement, compound 4: 2.1-fold (0.32 log units) below, within the range that was stated.
By their numbers in this assay, from the lowest: compounds 2, 3, 1 and 4 (each within the scatter of the next, the first and the last beyond it).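

Within the data shown here, compound 4 gives the first reading of the group on this carbonyl carbon with the rest of the molecule held constant: in this assay the change from morpholin-4-yl to butyl gives a 2.5-fold higher number from compound 2 to compound 4 (0.40 log units; beyond the scatter) and so makes the compound a weaker inhibitor. Among these compounds, the step is modest, yet it lies beyond the usual scatter, unlike the only earlier step, which concerned a different place in the molecule and stayed within it. This position can therefore shift the read-out, and in this pair the morpholin-4-yl group gives the lower number, although the change swaps a six-membered ring with its hydrogen-bond acceptor for an open chain, and no measurement here explains the shift.

The pair alone cannot separate the loss of the ring from the loss of its oxygen, a question that piperidin-1-yl on the same carbonyl carbon would address more directly. Also open, going by these compounds, is how an open chain other than butyl, such as a longer chain or one ending in an amine, would compare, and whether the same step appears when nitro replaces bromo on the shared core.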